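Cyclohexyl in place of pyridin-4-yl on a carbonyl carbon

The source may hold more compounds than are shown below. What is called first, only, known or untested is meant among the compounds shown, and "the series" means these compounds.

Measured in an ADME assay on cells (Hepatocyte, Mus musculus) for metabolic stability (on this read-out higher numbers stand for a longer-lived compound and lower numbers for a shorter-lived compound), so far:
compound 1 `O=C(OC1CCC(CN2CCN(c3cc(=O)c4cc(C(F)(F)F)cc([N+](=O)[O-])c4s3)CC2)CC1)c1ccccc1` gives 0.903 h
compound 2 `O=C(OC1CCC(CN2CCN(c3cc(=O)c4cc(C(F)(F)F)cc([N+](=O)[O-])c4s3)CC2)CC1)c1ccncc1` gives 0.0817 h
compound 3 `O=C(OC1CCC(CN2CCN(c3cc(=O)c4cc(C(F)(F)F)cc([N+](=O)[O-])c4s3)CC2)CC1)c1ccc(C(F)(F)F)cc1` gives 0.278 h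

Compound 2 holds the lowest of the three numbers, with compound 3 nearest and compound 1 furthest. The next compound to be read is compound 4 `O=C(OC1CCC(CN2CCN(c3cc(=O)c4cc(C(F)(F)F)cc([N+](=O)[O-])c4s3)CC2)CC1)C1CCCCC1` with cyclohexyl in place of pyridin-4-yl on a carbonyl carbon. Two measured steps replace or restore the same group. The large step of an 11-fold lower number from compound 1 to compound 2 (1.04 log units; beyond the scatter) puts pyridin-4-yl in place of phenyl, and the modest step of a 3.4-fold higher number from compound 2 to compound 3 (0.53 log units; beyond the scatter) puts 4-(trifluoromethyl)phenyl in place of pyridin-4-yl. The modest step of a 3.2-fold lower number from compound 1 to compound 3 (0.51 log units; beyond the scatter) shows that the two compounds without pyridin-4-yl also differ from each other. Among the compounds with values here, no cyclohexyl compound has been measured, so these steps guide the estimate only loosely. An upward step of modest size is expected in this assay on the strength of compound 2 sitting lowest at 0.0817 h and not on any direct precedent. The estimated step is a 4.3-fold higher number from compound 2 to compound 4 (0.63 log units; beyond the scatter) (expected, not measured). For compound 4 the expected value is 0.35 h (estimated range 0.1 h to 1.1 h).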

Compound 4, half-life: 0.0783 h
Compound 4: middle estimate off by 4.5-fold (0.65 log units), on the high side; measured number below the stated range.
By their numbers in this assay, from the lowest: compounds 4 and 2 (each within the scatter of the next); then compound 3; then compound 1.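

In this assay, swapping pyridin-4-yl for cyclohexyl on this carbonyl carbon gives a 1.0-fold lower number from compound 2 to compound 4 (0.02 log units; within the scatter), so an aromatic ring with a hetero atom and a non-aromatic ring of carbon only read alike here, and the short half-life of compound 2 does not depend on the pyridine nitrogen being present. Cyclohexyl stays well apart from both phenyl-based groups, with a 12-fold lower number from compound 1 to compound 4 (1.06 log units; beyond the scatter) and a 3.6-fold lower number from compound 3 to compound 4 (0.55 log units; beyond the scatter), so among these four compounds unsubstituted phenyl stands alone at the top and neither of the other ring types nor the trifluoromethyl-bearing phenyl comes close to it. No supporting data bear on why these rings rank as they do.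

Going by these compounds, it remains open whether other aromatic rings, such as thiophene, keep the phenyl value. Open chains on the carbonyl carbon, such as tert-butyl, and a methoxy group on the phenyl ring are also untested in this series.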